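The source may hold more compounds than are shown below. What is called first, only, known or untested is meant among the compounds shown, and "the series" means these compounds.

Working notes on the series. Compound 1 `CCC1=C(O)c2c(oc(-c3ccc(CC)cc3)cc2=O)C(CC)(CC)C1=O` gives the lowest number of the three measured compounds in a functional assay on KBVIN cells (Homo sapiens) for antiproliferative activity, read by sulforhodamine B assay, with a stated time of 3 days (on this read-out lower numbers stand for an effect already at smaller amounts and higher numbers for an effect only at larger amounts of compound), at 0.07 uM. Compound 2 `CCC1=C(O)c2c(oc(-c3ccc(O)cc3)cc2=O)C(CC)(CC)C1=O` gives 20.6 uM and compound 3 `CCC1=C(O)c2c(oc(-c3ccc(SC)cc3)cc2=O)C(CC)(CC)C1=O` gives 1.38 uM. The steps are a 290-fold higher number from compound 1 to compound 2 (2.47 log units; beyond the scatter), a 20-fold higher number from compound 1 to compound 3 (1.29 log units; beyond the scatter) and a 15-fold lower number from compound 2 to compound 3 (1.17 log units; beyond the scatter); both exchanges of the ethyl on the aromatic carbon for a group with a heteroatom raise the number well beyond the scatter, the hydroxy far more than the methylsulfanyl.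

Compound 4 `CCC1=C(O)c2c(oc(-c3cccc(C)c3)cc2=O)C(CC)(CC)C1=O` differs from compound 1 as follows: 3-methylphenyl in place of 4-ethylphenyl on an aromatic carbon. The measured steps bear on this only indirectly: each of them replaces the ethyl with a group containing oxygen or sulfur, whereas here a carbon-only substituent remains, shorter by one carbon and named 3-methylphenyl in place of 4-ethylphenyl. Nothing measured tells how a methyl at the other ring carbon behaves. Since every departure from 4-ethylphenyl seen so far, namely a 290-fold higher number from compound 1 to compound 2 (2.47 log units; beyond the scatter) and a 20-fold higher number from compound 1 to compound 3 (1.29 log units; beyond the scatter), raised the number, a rise is expected here too, but a smaller one, because 1.38 uM for compound 3 already shows that a small hydrophobic-looking exchange costs far less than hydroxy. For compound 4 the expected step is a 4.3-fold higher number from compound 1 to compound 4 (0.63 log units; beyond the scatter). For compound 4 the estimate in this assay is 0.3 uM, with a range from 0.07 uM to 1.4 uM.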

Compound 4, concentration for half-maximal effect: 3.69 uM
Estimate against measurement, compound 4: 12-fold (1.09 log units) below; the measured number lies above the stated range.
By their numbers in this assay, from the lowest: compound 1; then compound 3; then compound 4; then compound 2.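

In this assay, among these compounds, keeping the substituent free of heteroatoms does not preserve the low number of compound 1: 3-methylphenyl, with 0 hydrogen-bond donors and 0 hydrogen-bond acceptors like 4-ethylphenyl, gives a 53-fold higher number from compound 1 to compound 4 (1.72 log units; beyond the scatter), a larger step than the one to the methylsulfanyl compound. The carbon-only compound 4 also does not rank ahead of both heteroatom-bearing compounds, since a 2.7-fold higher number from compound 3 to compound 4 (0.43 log units; beyond the scatter) places it on the far side of the methylsulfanyl compound, while a 5.6-fold lower number from compound 2 to compound 4 (0.75 log units; beyond the scatter) leaves it well short of the hydroxy compound. Among the four compounds, the low number thus stays with 4-ethylphenyl alone, and no supporting data are available to account for the size of this loss.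

On these data alone, this exchange shortens the substituent by one carbon and also places it differently on the phenyl ring, so the share of each change in the step remains open. As far as these compounds go, it also remains open whether a propyl chain or an amine in place of the ethyl of 4-ethylphenyl would retain or lose the low number of compound 1.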